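The source may hold more compounds than are shown below. What is called first, only, known or untested is meant among the compounds shown, and "the series" means these compounds.

Measured compounds:
Compound 1, `Cc1ccccc1C(=O)Nc1ccc2nc(NC(=O)C3CCCCC3)sc2c1`: 0.085 ug/mL
Compound 2, `Cc1coc(C)c1C(=O)Nc1ccc2nc(NC(=O)C3CCCCC3)sc2c1`: 2.7 ug/mL
Compound 3, `O=C(Nc1ccc2nc(NC(=O)C3CCC3)sc2c1)c1c(Cl)cccc1Cl`: 0.013 ug/mL

In a functional assay on WI-38 VA13 cells (Homo sapiens) for cytotoxicity (a higher number here means that more compound is needed for the effect, a lower number that less compound is needed), compound 3 gives the lowest of the three numbers; compound 1 comes nearest, and compound 2 is furthest away. Among the compounds with values here, the one step measured between compounds that differ in a single place is a 32-fold higher number from compound 1 to compound 2 (1.50 log units; beyond the scatter), and that step changes the aryl group on the carbonyl carbon of the outer amide, not the group on the other carbonyl. Within the data shown here, compound 1 and compound 3 differ in two places at once, so their values show only that compound 3 gives a lower number.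

Compound 4, `O=C(Nc1nc2ccc(NC(=O)c3c(Cl)cccc3Cl)cc2s1)OCc1ccccc1`, differs from compound 3 in one place: benzyloxy in place of cyclobutyl on a carbonyl carbon. Among the measured compounds shown here, no measured step touches this side of the shared core, so the data give no direct guide to the size or direction of the change. Compound 4 is therefore expected to stay near compound 3, with a 2.3-fold higher number from compound 3 to compound 4 (0.36 log units; beyond the scatter) as the estimated step and a wide range around it. For compound 4 in this assay the estimate is 0.03 ug/mL, between 0.005 ug/mL and 0.2 ug/mL.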

Compound 4, half-maximal effective concentration: 0.018 ug/mL
Compound 4: middle estimate off by 1.7-fold (0.22 log units), on the high side; low and high end bracket the measured number.
By their numbers in this assay, from the lowest: compounds 3 and 4 (each within the scatter of the next); then compound 1; then compound 2.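

In this assay, within the data shown here, benzyloxy in place of cyclobutyl on a carbonyl carbon gives a 1.4-fold higher number from compound 3 to compound 4 (0.14 log units; within the scatter), the first measured step on this side of the shared core. Compound 3 and compound 4 therefore cannot be told apart here, even though the entering group carries more heavy atoms, an aromatic ring and a hydrogen-bond acceptor, whereas the earlier step on the other carbonyl was large, at a 32-fold higher number from compound 1 to compound 2 (1.50 log units; beyond the scatter). Nothing available explains this result.

As far as these compounds go, whether this position would accept an amine or a carboxylic acid on the same carbonyl carbon remains open. So does whether benzyloxy would give a similar result with 2,4-dimethylfuran-3-yl on the other carbonyl carbon.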